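Trifluoromethoxy for benzyloxy: what cytotoxicity to expect

The compounds below may be only part of what the source reports. "The series", "measured", "known", "first", "only" and "open" are said of these compounds alone.

Compound 1 `CCOC(=O)CCCCCOc1cccc(CN(C(=O)c2ccc(-c3cccc(OCC(C)C)c3)cc2)C(C)C)c1`, compound 2 `CCOC(=O)CCCCCOc1cccc(CN(C(=O)c2ccc(-c3cccc(OC(C)C)c3)cc2)C(C)C)c1` and compound 3 `CCOC(=O)CCCCCOc1cccc(CN(C(=O)c2ccc(-c3cccc(OCc4ccccc4)c3)cc2)C(C)C)c1` share one core and differ only in the group on an oxygen on an aromatic ring. In an ADME assay on Raji cells (Homo sapiens) for cytotoxicity, read by CellTiter-Glo and resazurin assay, with a stated time of 72 h (a higher number here means that more compound is needed for the effect, a lower number that less compound is needed), compound 1 gives > 26000 nM, a limit of the assay rather than a number. Compound 2 likewise gives a limit, > 26000 nM. Compound 3 also gives a limit, > 26000 nM. The steps a step that the two limits leave unreadable from compound 1 to compound 2, a step that the two limits leave unreadable from compound 1 to compound 3 and a step that the two limits leave unreadable from compound 2 to compound 3 are unreadable because every value sits at the limit of > 26000 nM in this assay, at which 3 of the 3 values shown sit. Compound 4 `CCOC(=O)CCCCCOc1cccc(CN(C(=O)c2ccc(-c3cccc(OC(F)(F)F)c3)cc2)C(C)C)c1` carries trifluoromethyl in place of benzyl on an oxygen on an aromatic ring. Within the data shown here, no measured step shows whether this change matters, so compound 4 is expected to remain near the limit, at 30000 nM with a range of 10000 nM to 100000 nM. The expected step that the limit leaves unreadable from compound 3 to compound 4 is none beyond the scatter.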

Compound 4, half-maximal effective concentration: > 26000 nM
Compound 4 gave a limit, no number; the forecaster's own chance of this, stated with the estimate: 80%; the middle value lies beyond the limit too.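

Among these compounds, no step from compound 1, compound 2 or compound 3 to compound 4 can be read, because all four values are limits rather than numbers: the limit of > 26000 nM in this assay, at which 4 of the 4 values shown sit. As far as these compounds go, whether any of these groups on the oxygen changes the result in this assay stays open.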